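The source may report more compounds than this note shows. Statements on the series, on what has been measured and on what is new or still open speak of the compounds shown alone.

Compound 1, `CCOC(=O)c1c(-c2cc3ccccc3oc2=O)nn(-c2cccc(C)c2)c1C(=O)OCC`, gives 52000 nM in a functional assay on A549 cells (Homo sapiens) for cytotoxicity, read by MTT assay, with a stated time of 48 h; a higher number here means a weaker inhibitor, a lower number a stronger inhibitor.
Compound 2, `CCOC(=O)c1c(-c2cc3ccc(OC)cc3oc2=O)nn(-c2cccc(C)c2)c1C(=O)OCC`, gives 171000 nM in this assay.
Compound 3, `CCOC(=O)c1c(-c2cc3ccc(OC)cc3oc2=O)nn(-c2cccc(Cl)c2)c1C(=O)OCC`, gives 221000 nM in this assay.

Among these three numbers compound 3 stands highest, though its value and that of compound 2 lie within the scatter of each other; compound 1 sits clearly lower. Compound 4, `CCOC(=O)c1c(-c2cc3ccc(OCC=C(C)C)cc3oc2=O)nn(-c2cccc(Cl)c2)c1C(=O)OCC`, differs from compound 3 by 2-methylprop-1-en-1-yl in place of hydrogen on a saturated chain carbon bound to an oxygen on an aromatic ring. Within the data shown here, no measured step touches the chain on that oxygen. Among the measured compounds shown here, the only related step is a 3.3-fold higher number from compound 1 to compound 2 (0.52 log units; beyond the scatter), where the methoxy first entered, and a 1.3-fold higher number from compound 2 to compound 3 (0.11 log units; within the scatter) is unrelated. The author therefore expects at most a small step in this assay, in no settled direction. Compound 4 is estimated at 200000 nM, between 80000 nM and 500000 nM, an expected step of a 1.1-fold lower number from compound 3 to compound 4 (0.04 log units; within the scatter).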

Compound 4, half-maximal inhibitory concentration: 163000 nM
Compound 4: the middle estimate sits 1.2-fold (0.09 log units) above what was measured, and the stated range covers the measured number.
By their numbers in this assay, from the lowest: compound 1; then compounds 4, 2 and 3 (each within the scatter of the next).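

Replacing the methoxy of compound 3 with (3-methylbut-2-en-1-yl)oxy gives a 1.4-fold lower number from compound 3 to compound 4 (0.13 log units; within the scatter) in this assay. The earlier compounds shown here showed only that methoxy in place of hydrogen on the aromatic carbon moved the number, a 3.3-fold higher number from compound 1 to compound 2 (0.52 log units; beyond the scatter), whereas this result shows that the chain on that oxygen can be extended with no step beyond the scatter. Nothing available here offers an explanation for this result.

The compounds shown leave open whether an amine or a carboxylic acid on this chain, or a longer saturated chain, would shift the number. They also leave open whether the same chain would behave alike with methyl in place of chloro.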